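This account rests on a few compounds, and the source may have more. Where it says the series, first, only, none or still open, it means among the compounds named here.

Values in a physicochemical assay for solubility, using the shake flask method, in simulated intestinal fluid, measured as kinetic solubility, with a stated time of 2 h, at 25 degrees C, at pH 6.5 (on this read-out higher numbers stand for higher solubility and lower numbers for lower solubility), for the measured compounds, each one a limit and not a number

- Compound 1 `COc1ccc(CN2C(=O)c3c(C)nc(-c4nc(C)no4)c(N)c3C2=O)cc1` gives < 5000 nM
- Compound 2 `Cc1noc(-c2nc(C)c3c(c2N)C(=O)N(Cc2ccccc2F)C3=O)n1` gives < 5000 nM
- Compound 3 `Cc1noc(-c2nc(C)c3c(c2N)C(=O)N(Cc2ccccc2C(F)(F)F)C3=O)n1` gives < 5000 nM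

Compound 3 sits at the limit of < 5000 nM in this assay, at which 3 of the 3 values shown sit, and has no exact number. The move to compound 4 `Cc1noc(-c2nc(C)c3c(c2N)C(=O)N(Cc2ccncc2)C3=O)n1` is pyridin-4-yl in place of 2-(trifluoromethyl)phenyl on a saturated chain carbon bound to an amide-type nitrogen in a ring and nothing else changes. Both a step that the two limits leave unreadable from compound 1 to compound 2 and a step that the two limits leave unreadable from compound 1 to compound 3 alter the group at this same place, and neither has a readable size. With no measured size to carry over, no step beyond the scatter is expected. The expected change is a step that the limit leaves unreadable from compound 3 to compound 4 by this estimate. In this assay the estimate for compound 4 is 3500 nM with 800 nM to 12000 nM as its expected range.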

Compound 4, solubility: 26400 nM
For compound 4 the middle estimate is 7.5-fold (0.88 log units) below the measured one, and the stated range ends below it.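

In this assay, the steps among compound 1, compound 2 and compound 3 cannot be read, as each of these compounds gives only a limit: the limit of < 5000 nM in this assay, at which 3 of the 4 values shown sit. Pyridin-4-yl on the saturated chain carbon bound to the amide-type nitrogen gives the first exact value and the first readable steps: an at least 5.2-fold higher number from compound 3 to compound 4 (0.72 log units; beyond the scatter), an at least 5.2-fold higher number from compound 2 to compound 4 (0.72 log units; beyond the scatter) and an at least 5.2-fold higher number from compound 1 to compound 4 (0.72 log units; beyond the scatter). Changing this one group can therefore move the read-out beyond the scatter.

Still open, as far as these compounds go, is how an unsubstituted phenyl, a pyridin-3-yl or a morpholine at this place would compare with pyridin-4-yl.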